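The source may hold more compounds than are shown below. What is called first, only, known or untested is meant among the compounds shown, and "the series" means these compounds.

From the compounds shown here alone, compound 2 `O=C1C(NC2CCCC2)=CC(=O)c2c1nc1n2[C@H]2OC[C@@H](O)[C@H]2OC1` stands at the edge of what can be read in a functional assay on MCF7 cells (Homo sapiens) for inhibition, read by sulforhodamine B assay; a lower number here means a stronger inhibitor, a higher number a weaker inhibitor: compound 2 gives only a limit, > 16000 nM, so its own number is unknown. The change to compound 4 `O=C1C(Nc2ccc(I)cc2)=CC(=O)c2c1nc1n2[C@H]2OC[C@@H](O)[C@H]2OC1` is 4-iodophenyl in place of cyclopentyl on an amine nitrogen. For the measured compounds named here, no measured step covers this change. Going by the values given here, the only measured step, an at least 1.7-fold higher number from compound 1 to compound 3 (0.25 log units; that floor lies within the scatter), concerns a different part of the molecule. Compound 1 `O=C1C=C(Nc2ccc(I)cc2)C(=O)c2c1nc1n2[C@H]2OC[C@@H](O)[C@H]2OC1` carries the same (4-iodophenyl)amino group but differs from compound 4 in more than one place; in this assay compound 1 gives 2230 nM. Compound 3 `O=C1C=C(Nc2ccc(C(F)(F)F)cc2)C(=O)c2c1nc1n2[C@H]2OC[C@@H](O)[C@H]2OC1` likewise gives only a limit in this assay, > 4000 nM. Taken together, the (4-iodophenyl)amino compound 1 yields a number where the cyclopentylamino compound 2 yields only a limit, which suggests the step from compound 2 to compound 4 is expected to lower the number, an at least 4.0-fold lower number from compound 2 to compound 4 (0.60 log units; beyond the scatter). Since compound 2 is known only as a limit, the size of that expected step is uncertain. For compound 4 the expected value in this assay is 4000 nM, within 1000 nM to 16000 nM.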

Compound 4, half-maximal inhibitory concentration: 3890 nM
Beside the measured number, compound 4's estimate is 1.0-fold (0.01 log units) above it; low and high end bracket the measured number.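

In this assay, 4-iodophenyl in place of cyclopentyl on the amine nitrogen gives an at least 4.1-fold lower number from compound 2 to compound 4 (0.61 log units; beyond the scatter). This is the only step shown at this place on the shared core, and it shows that the group on this nitrogen can move the read-out by more than the usual scatter, with the aromatic ring carrying iodine giving the stronger inhibitor of this pair. Only the lower bound of the step is known, because compound 2 gives a limit rather than a number: the limit of > 16000 nM in this assay, at which 1 of the 4 values shown sits.

The pair cannot separate the contribution of the aromatic ring from that of the iodine, which a plain phenyl or a 4-chlorophenyl group on the same nitrogen would help to resolve. From the compounds shown here alone, how a non-aromatic group other than cyclopentyl, such as a longer alkyl chain, would read at this place also remains open.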